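From cyclopropyl to 4-ethoxyphenyl on the amine nitrogen

This account rests on a few compounds, and the source may have more. Where it says the series, first, only, none or still open, it means among the compounds named here.

Measured in a functional assay on MGC-803 cells (Homo sapiens) for inhibition, read by sulforhodamine B assay; a lower number here means a stronger inhibitor, a higher number a weaker inhibitor:
Compound 1 `CCc1ccc(NC2=CC(=O)c3c(nc4n3[C@H]3OC[C@@H](O)[C@H]3OC4)C2=O)cc1`: 1110 nM
Compound 2 `Cc1ccc(NC2=CC(=O)c3c(nc4n3[C@H]3OC[C@@H](O)[C@H]3OC4)C2=O)cc1C`: 1050 nM
Compound 3 `O=C1C(NC2CC2)=CC(=O)c2c1nc1n2[C@H]2OC[C@@H](O)[C@H]2OC1`: > 4000 nM (a limit, not a number)

Compound 3 is the only one of the three without a number. Its reading is the limit of > 4000 nM in this assay, at which 1 of the 3 values shown sits. Compound 4 `CCOc1ccc(NC2=CC(=O)c3c(nc4n3[C@H]3OC[C@@H](O)[C@H]3OC4)C2=O)cc1` shares the core of compound 3 and differs at one place: 4-ethoxyphenyl in place of cyclopropyl on an amine nitrogen. In words, 4-ethoxyphenyl stands in place of cyclopropyl on an amine nitrogen.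

Two measured steps make the reverse kind of change, with cyclopropyl entering in place of a substituted phenyl group. They show an at least 3.6-fold higher number from compound 1 to compound 3 (0.55 log units; beyond the scatter) and an at least 3.8-fold higher number from compound 2 to compound 3 (0.58 log units; beyond the scatter). A third step compares the two phenyl-bearing compounds and shows a 1.1-fold lower number from compound 1 to compound 2 (0.02 log units; within the scatter), so changing the groups on that ring made no difference that can be told from scatter in this pair.

Compound 4 also carries a substituted phenyl group, so it is expected to fall close to compound 1 and compound 2 in this assay, with a lower number than the limit seen for compound 3. Within the data shown here, none of the measured compounds carries the ethoxy group, so the range is kept wide.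

The expected change is an at least 3.6-fold lower number from compound 3 to compound 4 (0.56 log units; beyond the scatter).

Compound 4 is estimated at 1100 nM, with an expected range of 500 nM to 2400 nM.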

Compound 4, half-maximal inhibitory concentration: 2090 nM
Compound 4: middle estimate off by 1.9-fold (0.28 log units), on the low side, within the range that was stated.
By their numbers in this assay, from the lowest: compounds 2, 1 and 4 (each within the scatter of the next). At a limit, above all of these: compound 3.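

In this assay, compound 4 is the third compound with a substituted phenyl group on the amine nitrogen, and it shows how little the groups on that ring have changed the reading so far. Placing ethoxy in place of ethyl gives a 1.9-fold higher number from compound 1 to compound 4 (0.27 log units; within the scatter), and 4-ethoxyphenyl in place of 3,4-dimethylphenyl gives a 2.0-fold higher number from compound 2 to compound 4 (0.30 log units; within the scatter), so neither change can be told from repeat-measurement noise. Against cyclopropyl the result is an at least 1.9-fold lower number from compound 3 to compound 4 (0.28 log units; that floor lies within the scatter), and the true size of this step stays unknown because compound 3 carries a limit rather than a number: the limit of > 4000 nM in this assay, at which 1 of the 4 values shown sits.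

The compounds shown leave open how an unsubstituted phenyl, a benzyl group, a longer alkyl chain, or a phenyl ring carrying an amine or a carboxylic acid would read on this nitrogen. Among these compounds, with cyclopropyl as the only group here that is not a substituted phenyl, they also leave open whether the aromatic ring itself matters or whether other groups of similar size on the nitrogen would read the same in this assay.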